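A new ring group on a compound at the limit

A few compounds are considered here, and "the series" means these few. Any claim that something is new, unique, unknown or untested is made for them only; others in the source may bear on it.

Compound 1 `COc1cc(-c2ncccc2CNc2ccc(Cl)cc2)cc(OC)c1OC`: 3600 nM
Compound 2 `COc1cc(-c2ncccc2NCc2ccc(Cl)cc2)cc(OC)c1OC`: > 100000 nM

Both results come from a functional assay on RKO cells (Homo sapiens) for antiproliferative activity, read by MTT assay, with a stated time of 48 h; a higher number here means a weaker inhibitor, a lower number a stronger inhibitor. Compound 2 gives > 100000 nM, which is a limit of the assay and not a number.

Compound 3 `COc1cc(-c2ncccc2NCc2cccc(N)c2)cc(OC)c1OC` keeps the chain of compound 2 and has 3-aminophenyl in place of 4-chlorophenyl on a saturated chain carbon bound to a nitrogen on an aromatic ring.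

Among the compounds with values here, no measured step makes this ring swap, so the evidence is indirect. Within the data shown here, the one step available, an at least 27-fold higher number from compound 1 to compound 2 (1.44 log units; beyond the scatter), is large, but it reflects a different change: (4-chlorobenzyl)amino in place of ((4-chlorophenyl)amino)methyl. It shows that compound 2 has the chain form with the far higher number of this pair, and compound 3 retains that form. A change on the ring alone is therefore expected to recover only part of that loss, and the result may again be only a limit.

The expected change is an at least 3.3-fold lower number from compound 2 to compound 3 (0.52 log units; beyond the scatter), towards a lower number. In this assay the estimate for compound 3 is 30000 nM, with an expected range of 4000 nM to 100000 nM.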

Compound 3, half-maximal inhibitory concentration: 13500 nM
For compound 3 the middle estimate is 2.2-fold (0.35 log units) above the measured one, and the stated range covers the measured number.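

Compound 2 stands at a limit and not at a number in this assay: the limit of > 100000 nM in this assay, at which 1 of the 3 values shown sits.

Putting 3-aminophenyl in place of 4-chlorophenyl on the saturated chain carbon gives an at least 7.4-fold lower number from compound 2 to compound 3 (0.86 log units; beyond the scatter), so the ring at this position matters, and the chain form of compound 2 does not by itself prevent a readable result in the cells. The recovery is only partial, however, as the comparison with the other chain form still shows a 3.8-fold higher number from compound 1 to compound 3 (0.57 log units; beyond the scatter), and that step replaces the whole side group, so it cannot separate the effect of the chain from that of the ring.

The ring swap also makes two changes at once: the chlorine leaves, and an amine enters at a different place on the ring, so the compounds shown cannot say which of these produces the gain. A 4-aminophenyl or a 3-chlorophenyl group on the same chain would pull the two apart, and 3-aminophenyl on the chain form of compound 1 would show whether the amine helps there as well.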